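Ring in place of iodoethenyl: compound 2 to compound 4

The source may report more compounds than this note shows. Statements on the series, on what has been measured and on what is new or still open speak of the compounds shown alone.

Three compounds have values in an ADME assay on L1210/0 cells (Mus musculus) for cytotoxicity, with a stated time of 48 h; a higher number here means a weaker inhibitor, a lower number a stronger inhibitor. Compound 1 `Nc1nc(Cl)c2nnn([C@H]3CCCC[C@H]3CO)c2n1` gives 95500 nM in this assay. Compound 2 `O=c1[nH]c(=O)n([C@H]2C[C@H](O)[C@@H](CO)O2)cc1/C=C/I` gives 63900 nM in this assay; it is the lower of the two plain numbers, yet it lies within the scatter of compound 1, so no order between them can be claimed. Compound 3 `CC1(C)[C@@H](CCCO)C[C@H]1n1nnc2c(N)nc(N)nc21` gives > 200000 nM, a limit of this assay rather than a number, namely (the limit of > 200000 nM in this assay, at which 1 of the 3 values shown sits). Within the data shown here, no measured pair differs in one place only. Compound 4 `O=c1[nH]c(=O)n([C@H]2C[C@H](O)[C@@H](CO)O2)cc1C1SCCS1` differs from compound 2 by a group of 5 heavy atoms (3 carbon, 2 sulfur; one five-membered non-aromatic ring with 2 hetero atoms) in place of a group of 3 heavy atoms (2 carbon, 1 iodine; no ring), on an aromatic carbon. Lacking any measured step of this kind, the expectation is a change within the scatter, or at most a modest weakening. The estimate for compound 4 in this assay is 85000 nM, with a range from 25000 nM to 250000 nM. That expected value means a step of a 1.3-fold higher number from compound 2 to compound 4 (0.12 log units; within the scatter).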

Compound 4, half-maximal inhibitory concentration: > 200000 nM
Compound 4: a limit, no number; the forecaster's own chance of this, stated with the estimate: 30%; at least 2.3-fold (0.37 log units) between middle value and limit.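

Among these compounds, the first one-place step falls on this aromatic carbon: in this assay, the five-membered ring with 2 hetero atoms in place of 2-iodoethenyl gives an at least 3.1-fold higher number from compound 2 to compound 4 (0.49 log units; beyond the scatter). This position is therefore not indifferent to the group it carries, at least for these two groups. Compound 4 gives a limit, not a number, so the step has a lower bound only: the limit of > 200000 nM in this assay, at which 2 of the 4 values shown sit.

On these data alone, whether the shift follows from losing the iodine, losing the double bond or gaining the ring stays open. A plain ethyl, a 2-bromoethenyl or an amine on the same carbon would separate these readings.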